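Chalcone series, cytotoxicity, a thioether replaces a halogen

This account rests on a few compounds, and the source may have more. Where it says the series, first, only, none or still open, it means among the compounds named here.

Working notes on the series. The read-out throughout is a functional assay on RL cells (Homo sapiens) for cytotoxicity, with a stated time of 48 h; on this read-out higher numbers stand for weaker inhibition and lower numbers for stronger inhibition. Compound 1 `COc1cc(O)c(C(=O)/C=C/c2ccc(F)cc2)c(OC)c1` gives 5400 nM in this assay. Compound 2 `COc1cc(OC)c(C(=O)/C=C/c2ccc(Cl)cc2)c(OC)c1` gives 6500 nM in this assay. Compound 3 `COc1cccc(/C=C/C(=O)c2c(O)cc(OC)cc2OC)c1` gives 9000 nM in this assay. Among these three numbers compound 2 holds the second highest, with compound 1 nearest and compound 3 furthest, and both gaps fall inside the usual scatter of repeated measurements; no ordering among the three can be claimed. Within the data shown here, no pair of measured compounds differs in only one place, so no measured step is available to guide the next change.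

Compound 4 `COc1cc(OC)c(C(=O)/C=C/c2ccccc2SC)c(OC)c1` is not yet measured. It differs from compound 2 as follows: 2-(methylsulfanyl)phenyl in place of 4-chlorophenyl on a double-bonded chain carbon bound to a double-bonded chain carbon.

Among the measured compounds shown here, with no measured step of this kind and all three measured values sitting within scatter of one another, no shift beyond the scatter is expected in this assay. Compound 4 is estimated at 6500 nM, with a range of 2500 nM to 17000 nM. The step expected is no change at the digits printed from compound 2 to compound 4 (within the scatter), which would leave compound 4 alongside compound 2.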

Compound 4, half-maximal inhibitory concentration: 8300 nM
Beside the measured number, compound 4's estimate is 1.3-fold (0.11 log units) below it, and the stated range covers the measured number.
By their numbers in this assay, from the lowest: compounds 1, 2, 4 and 3 (each within the scatter of the next).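

In this assay the series now has its first measured step between compounds that differ in one place, and it reads a 1.3-fold higher number from compound 2 to compound 4 (0.11 log units; within the scatter). At the place on a double-bonded chain carbon bound to a double-bonded chain carbon, 2-(methylsulfanyl)phenyl can therefore stand in for 4-chlorophenyl, bringing sulfur in for chlorine and one hydrogen-bond acceptor, with no difference that can be read from the scatter. Nothing available explains why this exchange leaves the number within the scatter.

Going by these compounds, whether any group at this place can move the number beyond the scatter remains open, for example an amine or a carboxylic acid on the ring. Among these compounds, with only this one step, it is also open whether the result holds on the cores of compound 1 and compound 3.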